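The source may report more compounds than this note shows. Statements on the series, on what has been measured and on what is new or still open speak of the compounds shown alone.

Measured compounds:
Compound 1, `Cc1ccc([N+](=O)[O-])cc1S(=O)(=O)N(C)/N=C/c1cnn2ccc(Cl)cc12`, in an assay on isolated protein for inhibition of phosphatidylinositol 4,5-bisphosphate 3-kinase catalytic subunit beta isoform (Homo sapiens), read by 33P incorporation, with a stated time of 60 min (a lower number here means a stronger inhibitor, a higher number a weaker inhibitor), gives 390 nM.
Compound 2, `C#Cc1ccn2ncc(/C=N/N(C)S(=O)(=O)c3cc([N+](=O)[O-])ccc3C)c2c1`, in this assay gives 30 nM.

Among the compounds with values here, of the two numbers, compound 2 holds the lower one; the only other compound, compound 1, sits higher, and the step of a 13-fold lower number from compound 1 to compound 2 (1.11 log units; beyond the scatter) is the single measured step in this set, an exchange of chloro for ethynyl on an aromatic carbon of the shared core. Compound 3, `Cc1ccc([N+](=O)[O-])cc1S(=O)(=O)N(C)/N=C/c1cnn2ccc(C(N)=O)cc12`, has not yet been measured in this assay. It differs from compound 2 by carbamoyl in place of ethynyl on an aromatic carbon. Within the data shown here, no measured step bears directly on this exchange: the one step known, from chloro to ethynyl, says nothing about what a carbamoyl group does at that place, and the group entering is unlike either of the groups measured there. The direction of the change is therefore open; a loss against compound 2 seems about as plausible as no change, and the estimate carries a wide range. For compound 3 in this assay the expected value is 100 nM, between 15 nM and 700 nM, which corresponds to an expected step of a 3.3-fold higher number from compound 2 to compound 3 (0.52 log units; beyond the scatter).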

Compound 3, half-maximal inhibitory concentration: > 1000 nM
Compound 3: no number, only a limit (the forecaster's own chance of this, stated with the estimate: 5%); middle value at least 10-fold (1.00 log units) away from the limit.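

Compound 3 gives no number in this assay, only a limit: the limit of > 1000 nM in this assay, at which 1 of the 3 values shown sits.

Exchanging the ethynyl group for carbamoyl at this aromatic carbon, opposite the ring nitrogen, gives a large step in the weaker direction (an at least 33-fold higher number from compound 2 to compound 3 (1.52 log units; beyond the scatter)), so the gain seen on going from chloro to ethynyl does not carry over to every group placed here. Carbamoyl also falls behind chloro itself (an at least 2.5-fold higher number from compound 1 to compound 3 (0.40 log units; beyond the scatter)), which puts the three groups in the order ethynyl, chloro, carbamoyl, from strongest to weakest inhibitor, and shows that this place can lose activity as well as gain it.

The limit hides how far compound 3 really falls, and the three compounds cannot tell whether the loss belongs to the hydrogen-bond donor and acceptor that carbamoyl brings or to some other difference between the groups. A nitrile, a primary amine or a propynyl chain at this same place would remain to be compared with ethynyl and carbamoyl before any rule for this position could be drawn.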